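Thiophene for trimethoxyphenyl on the shorter-linker core

The compounds below may be only part of what the source reports. "The series", "measured", "known", "first", "only" and "open" are said of these compounds alone.

Compound 2 `COc1cc(/C=C/C(=O)/C=C/c2cc(OC)c(OC)c(OC)c2)ccc1OCc1cn(CCCCCOc2cc(=O)oc3ccccc23)nn1` and compound 1 `COc1cc(/C=C/C(=O)/C=C/c2cccs2)ccc1OCc1cn(CCCCCOc2cc(=O)oc3ccccc23)nn1` share one core and differ by thiophen-2-yl in place of 3,4,5-trimethoxyphenyl on a double-bonded chain carbon bound to a double-bonded chain carbon. In a functional assay on THP-1 cells (Homo sapiens) for inhibition, read by sulforhodamine B assay, with a stated time of 48 h, tested at 50 uM (a higher number here means more inhibition of growth at the concentration tested, a lower number less inhibition of growth), compound 2 gives 55% and compound 1 gives 34%; the step of a number 21 percentage points lower from compound 2 to compound 1 (beyond the scatter). Compound 3 `COc1cc(/C=C/C(=O)/C=C/c2cc(OC)c(OC)c(OC)c2)ccc1OCc1cn(CCCOc2cc(=O)oc3ccccc23)nn1` carries the trimethoxyphenyl group on a second core; the difference between the two cores is not broken down here. In this assay compound 3 gives 79%, the highest of the three numbers, with both steps to the other compounds beyond the scatter.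

Compound 4 `COc1cc(/C=C/C(=O)/C=C/c2cccs2)ccc1OCc1cn(CCCOc2cc(=O)oc3ccccc23)nn1` has not been measured in this assay. It differs from compound 3 by thiophen-2-yl in place of 3,4,5-trimethoxyphenyl on a double-bonded chain carbon bound to a double-bonded chain carbon, the same change as from compound 2 to compound 1, at the same place. Among the compounds with values here, the step is expected to be a number 21 percentage points lower from compound 3 to compound 4 (beyond the scatter), of about the size of the earlier one, because compound 2 to compound 1 gave a number 21 percentage points lower from compound 2 to compound 1 (beyond the scatter); that the change behaves alike on the second core is an assumption, since only one earlier instance exists. Compound 4 is therefore estimated at 58%, most likely between 42% and 74%.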

Compound 4, percent growth inhibition at one concentration: 54%
Estimate against measurement, compound 4: 4 percentage points above, and the stated range covers the measured number.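

In this assay, thiophen-2-yl in place of 3,4,5-trimethoxyphenyl on a double-bonded chain carbon bound to a double-bonded chain carbon gives a number 25 percentage points lower from compound 3 to compound 4 (beyond the scatter), and the step agrees with the earlier one: the same change on two cores in this assay, a number 21 percentage points lower (beyond the scatter) from compound 2 to compound 1 and a number 25 percentage points lower (beyond the scatter) from compound 3 to compound 4, 4 percentage points apart, within the scatter of two such steps

On these two cores, then, the change can be carried across as a step of about the same size, and the core of compound 3 keeps its higher reading with either group in place. This rests on two pairs in one growth-inhibition read-out at a single tested concentration, so it does not show that the step holds on any other core, and it gives no reason for the loss.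

On these data alone, it remains open whether the step follows from the thiophen-2-yl itself or from the loss of the 3,4,5-trimethoxyphenyl, and a plain phenyl or a furan-2-yl at the same place would help separate the two. Also open, as far as these compounds go, is whether the step keeps its size with a longer chain on the core.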